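This account rests on a few compounds, and the source may have more. Where it says the series, first, only, none or still open, it means among the compounds named here.

Compound 1 `CCCCCCC#Cc1cc2cn(COCCO)c(=O)nc2o1`: > 200000 nM
Compound 2 `CCCCCC#Cc1cc2cn(COCCO)c(=O)nc2o1`: >= 100000 nM

In a functional assay on HEL cells (Homo sapiens), read by microscopy (on this read-out higher numbers stand for lower toxicity in this test and lower numbers for higher toxicity in this test), compound 2 reaches only a limit of the test, >= 100000 nM. Compound 1 likewise gives only a limit, > 200000 nM. The step that the two limits leave unreadable from compound 1 to compound 2 therefore cannot be read in size. Compound 3 `CCCCCCCCCC#Cc1cc2cn(COCCO)c(=O)nc2o1` differs from compound 2 by butyl in place of hydrogen on a saturated chain carbon, five bonds along the chain from a triple-bonded carbon. No readable step bears on this change, so no shift beyond the usual scatter is expected in this assay. Compound 3 is expected to show a step that the limit leaves unreadable from compound 2 to compound 3. Compound 3 is estimated at 150000 nM, between 60000 nM and 400000 nM, most probably again reported only as a limit.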

Compound 3, minimum cytotoxic concentration: >= 20000 nM
Compound 3: a limit, no number; the forecaster's own chance of this, stated with the estimate: 85%; the middle value does not contradict the limit.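

For the compounds shown here, compound 1, compound 2 and compound 3 each give only a limit in this assay, so no step among them can be read. From the compounds shown here alone, whether the longer chains change toxicity at all remains open.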